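This account rests on a few compounds, and the source may have more. Where it says the series, first, only, none or still open, it means among the compounds named here.

Compound 1 `COc1cccc2sc(NC(=O)c3ccc(C(F)(F)F)cc3)nc12` and compound 2 `COc1ccc2sc(NC(=O)c3ccc(C)cc3)nc2c1` share one core and both were tested for growth inhibition. In a functional assay on NUGC-3 cells (Homo sapiens) for antiproliferative activity, read by sulforhodamine B assay (on this read-out higher numbers stand for weaker inhibition of growth and lower numbers for stronger inhibition of growth), compound 1 gives > 10 ug/mL, which is a limit of the assay rather than a number. In this assay compound 2 gives > 10 ug/mL, again a limit. Where compound 2 stands is therefore known only this far: it sits at the limit, a point summarised by the limit of > 10 ug/mL in this assay, at which 2 of the 2 values shown sit, which covers every value recorded. Compound 3 `COc1ccc(C(=O)Nc2nc3cc(OC)ccc3s2)cc1` has not yet been measured. It differs from compound 2 in that (methoxy in place of methyl on an aromatic carbon), methoxy in place of methyl on an aromatic carbon. Within the data shown here, no measured step connects such a pair. Because the limit of > 10 ug/mL in this assay, at which 2 of the 2 values shown sit, is where both recorded values sit, the step that the limit leaves unreadable from compound 2 to compound 3 is expected to be none beyond the scatter. Compound 3 is thus estimated at 15 ug/mL, within a range from 5 ug/mL to 50 ug/mL, and is expected most often to return only a limit.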

Compound 3, concentration for 50% growth inhibition: > 10 ug/mL
Compound 3: no number, only a limit (the forecaster's own chance of this, stated with the estimate: 80%); the middle value lies beyond the limit too.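

In this assay compound 2 and compound 3 each return only a limit of the assay, so no step can be read for methoxy in place of methyl. The compounds shown leave open how strongly any of them inhibits growth: the limit of > 10 ug/mL in this assay, at which 3 of the 3 values shown sit.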